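A Chloro-to-Hydroxy Swap on the Anilide Ring

The compounds below may be only part of what the source reports. "The series", "measured", "known", "first", "only" and "open" are said of these compounds alone.

Compound 1 `O=C(CSC(=S)N[C@H]1CCOC1=O)Nc1cccc(Cl)c1`: 107000 nM
Compound 2 `O=C(CSC(=S)N[C@H]1CCOC1=O)Nc1cccc(C(F)(F)F)c1`: 79700 nM

In a functional assay on EC9706 cells (Homo sapiens) for cytotoxicity, read by MTT assay, with a stated time of 72 h (on this read-out lower numbers stand for stronger inhibition and higher numbers for weaker inhibition), compound 1 gives 107000 nM, the higher of the two numbers seen so far. Its nearest neighbour is compound 2, which gives 79700 nM; the step of a 1.3-fold lower number from compound 1 to compound 2 (0.13 log units; within the scatter) stays within the scatter. Compound 3 `O=C(CSC(=S)N[C@H]1CCOC1=O)Nc1ccc(O)cc1` has not been measured. It differs from compound 1 by 4-hydroxyphenyl in place of 3-chlorophenyl on an amide-type nitrogen. Among the compounds with values here, the single measured step, exchanging chloro for trifluoromethyl, was small and concerns a different change, so nothing in the data supports expecting a shift beyond the scatter in this assay. Compound 3 is therefore expected to give about 150000 nM, within a range from 60000 nM to 400000 nM. The step expected is a 1.4-fold higher number from compound 1 to compound 3 (0.15 log units; within the scatter).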

Compound 3, half-maximal inhibitory concentration: > 128000 nM
Compound 3 gave a limit, no number; the forecaster's own chance of this, stated with the estimate: 25%; the middle value does not contradict the limit.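

In this assay compound 3 gives > 128000 nM, which is a limit of the assay and not a number. The exchange of 3-chlorophenyl for 4-hydroxyphenyl on an amide-type nitrogen gives an at least 1.1-fold higher number from compound 1 to compound 3 (0.07 log units; that floor lies within the scatter), so only a floor is known for this step. Unlike the earlier step between compounds with measured values, this one has no readable size, and it does not show whether the change at this position moves the number beyond the scatter. Going by these compounds, whether an aminophenyl or a methoxyphenyl group at this place would give a measurable number stays open.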